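A few compounds are considered here, and "the series" means these few. Any claim that something is new, unique, unknown or untested is made for them only; others in the source may bear on it.

In a physicochemical assay for solubility, in phosphate buffer, at pH 7.4 (on this read-out lower numbers stand for lower solubility and higher numbers for higher solubility), three compounds sharing one core have been measured. Compound 1 `OCCC1CCN(c2nccnc2OC2CN(c3ccc4ccccc4n3)C2)CC1` gives 84000 nM, compound 2 `COCC1CCN(c2nccnc2OC2CN(c3ccc4ccccc4n3)C2)CC1` gives 53000 nM, and compound 3 `CN(C)C1CCN(c2nccnc2OC2CN(c3ccc4ccccc4n3)C2)CC1` gives 500000 nM, the highest of the three numbers. Compound 4 `NC(=O)C1CCN(c2nccnc2OC2CN(c3ccc4ccccc4n3)C2)CC1` has not yet been measured. It differs from compound 3 by carbamoyl in place of dimethylamino on a saturated ring carbon. For the measured compounds named here, no measured step carries this exact change, but two steps end at the dimethylamino group: a 6.0-fold higher number from compound 1 to compound 3 (0.77 log units; beyond the scatter) and a 9.4-fold higher number from compound 2 to compound 3 (0.97 log units; beyond the scatter), both beyond the scatter. The third step, a 1.6-fold lower number from compound 1 to compound 2 (0.20 log units; within the scatter), lies within the scatter, so compound 1 and compound 2 offer a single level to return to. Going by the values given here, compound 4 also lacks the dimethylamino group, so a fall of similar size is expected in this assay, although no carbamoyl compound has been measured to confirm it. The expected change is an 8.3-fold lower number from compound 3 to compound 4 (0.92 log units; beyond the scatter). Compound 4 is estimated at 60000 nM, with an expected range of 20000 nM to 160000 nM.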

Compound 4, solubility: 14000 nM
For compound 4 the middle estimate is 4.3-fold (0.63 log units) above the measured one; measured number outside the range, below it.
By their numbers in this assay, from the lowest: compound 4; then compounds 2 and 1 (each within the scatter of the next); then compound 3.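

In this assay, carbamoyl in place of dimethylamino on this saturated ring carbon gives a 36-fold lower number from compound 3 to compound 4 (1.55 log units; beyond the scatter), the largest step in the series. The position therefore does not have one shared level for groups other than dimethylamino: carbamoyl also stands apart from the methoxymethyl and 2-hydroxyethyl groups, with a 3.8-fold lower number from compound 2 to compound 4 (0.58 log units; beyond the scatter) and a 6.0-fold lower number from compound 1 to compound 4 (0.78 log units; beyond the scatter), which makes compound 4 the lowest of the four. Nothing measured here accounts for this difference between the groups.

On these data alone, it remains open whether a primary amine or a cyclic amine on the same ring carbon would stand near compound 3. As far as these compounds go, it is equally open whether a carboxylic acid or a carbamoylmethyl group would stay near compound 4 or move toward compound 1 and compound 2.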